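The source may report more compounds than this note shows. Statements on the series, on what has been measured and on what is new or still open speak of the compounds shown alone.

Notes on the series. Compound 1 `N#CC1=C(N)Oc2c(c3nc4ccccc4nc3c3ccccc23)C12C(=O)N(Cc1cnnn1-c1ccc(Cl)cc1)c1ccccc12` and compound 2 `Cc1ccccc1-n1nncc1CN1C(=O)C2(C(C#N)=C(N)Oc3c(N)cc4nc5ccccc5nc4c32)c2ccccc21` have both been run in a functional assay on MCF7 cells (Homo sapiens) for antiproliferative activity, read by MTT assay, with a stated time of 48 h; on this read-out lower numbers stand for stronger inhibition and higher numbers for weaker inhibition. In this assay compound 1 returns only the limit > 50000 nM, not a number. Compound 2 likewise returns only the limit > 50000 nM in this assay. Compound 2 therefore stands at the limit of > 50000 nM in this assay, at which 2 of the 2 values shown sit. Compound 3 `N#CC1=C(N)Oc2c(N)cc3nc4ccccc4nc3c2C12C(=O)N(Cc1cnnn1-c1c(F)cccc1F)c1ccccc12` is not yet measured; it differs from compound 2 by 2,6-difluorophenyl in place of 2-methylphenyl on an aromatic nitrogen. Given that compound 2 shows only the limit > 50000 nM, a step of no size beyond the scatter is expected. For compound 3 the estimate in this assay is 50000 nM, range 20000 nM to 120000 nM, implying a number no higher from compound 2 to compound 3 (the limit leaves the size open).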

Compound 3, half-maximal inhibitory concentration: > 50000 nM
Compound 3 was reported as a limit; the forecaster's own chance of this, stated with the estimate: 80%; the middle value lies on the limit itself.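

Compound 2 and compound 3 both return only a limit in this assay, so no step can be read between them: the limit of > 50000 nM in this assay, at which 3 of the 3 values shown sit.

The compounds shown leave open how the groups on the aromatic nitrogen rank against one another.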